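A few compounds are considered here, and "the series" means these few. Any claim that something is new, unique, unknown or untested is made for them only; others in the source may bear on it.

Of the compounds shown here, three have so far been measured in a physicochemical assay for acid dissociation, using potentiometric titration, and a fourth, compound 4, `CCc1c(O)c(=O)ccn1CCN(C)C`, awaits its turn. Compound 1, `O=c1ccn(CCN2CCCCC2)c(CO)c1O`, gives 2.25 in this assay. Compound 3, `CC(O)c1c(O)c(=O)ccn1CCN1CCCCC1`, gives 2.17. Compound 2, `Cc1c(O)c(=O)ccn1CCN(C)C`, gives 2.74, the highest of the three numbers, set apart from compound 1 and from compound 3 by more than the scatter. How the core of compound 2 differs from the core of compound 1 is not broken down here.

The change from compound 1 to compound 3 is methyl in place of hydrogen on a saturated chain carbon bound to an aromatic carbon and an oxygen on a saturated carbon, and it made a step of a number 0.08 log units lower from compound 1 to compound 3 (within the scatter). The change that turns compound 2 into compound 4 is methyl in place of hydrogen on a saturated chain carbon bound to an aromatic carbon. It is the same kind of change, though in compound 1 the saturated chain carbon is bound to an aromatic carbon and an oxygen on a saturated carbon, while in compound 2 it is bound only to an aromatic carbon. Resting on the earlier step of a number 0.08 log units lower from compound 1 to compound 3 (within the scatter), which stayed within the scatter, a step of a number 0.04 log units lower from compound 2 to compound 4 (within the scatter) is expected. Compound 4 is therefore estimated at 2.7, expected between 2.4 and 3.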

Compound 4, acid dissociation constant: 2.62
Compound 4: the middle estimate sits 0.08 log units above what was measured; the range from low to high includes it.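

In this assay the swap of methyl in place of hydrogen gave a number 0.12 log units lower from compound 2 to compound 4 (within the scatter) and, on the other core, it gave a number 0.08 log units lower from compound 1 to compound 3 (within the scatter) as well. Among these compounds, in these two pairs, then, the change carried from one core to the other without a step that stands out from the ordinary spread of repeated measurements, which is useful to know but rests on only two pairs and does not show that the change has no effect at all, since a small real step could hide inside that spread. Nothing available here bears on why the read-out holds so steady across this change.

The compounds shown leave open whether a longer chain such as propyl, or a larger swap such as an amine or a carboxylic acid, on the same saturated chain carbon would also stay within the scatter. They also leave open whether the methyl swap would behave the same way on a third core.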